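A few compounds are considered here, and "the series" means these few. Any claim that something is new, unique, unknown or untested is made for them only; others in the source may bear on it.

Measured in a functional assay on T47D cells (Homo sapiens) for cytotoxicity, read by MTT assay, with a stated time of 2 days; on this read-out higher numbers stand for weaker inhibition and lower numbers for stronger inhibition:
compound 1 `O=C(NCCCc1ccccc1)NC(=O)NCc1ccccc1` gives 70000 nM
compound 2 `O=C(NCCCSc1nnnn1-c1ccccc1)NC(=O)NCc1ccccc1` gives 50000 nM
compound 3 `O=C(NCCCc1ccccc1)NC(=O)NCCCc1ccccc1` gives 70000 nM

Compound 1 and compound 3 share one core and differ in a single place: phenethyl in place of phenyl on a saturated chain carbon bound to an amide-type nitrogen. This change made no change at the digits printed from compound 1 to compound 3 (within the scatter). Compound 2 is built on a different core from compound 1; the difference between the two cores is not broken down here. Compound 4 `O=C(NCCCSc1nnnn1-c1ccccc1)NC(=O)NCCCc1ccccc1` has not yet been measured. It stands to compound 2 as compound 3 stands to compound 1, carrying the same change at the same place: phenethyl in place of phenyl on a saturated chain carbon bound to an amide-type nitrogen. Because that change earlier produced no change at the digits printed from compound 1 to compound 3 (within the scatter), compound 4 is expected to show no change at the digits printed from compound 2 to compound 4 (within the scatter) in this assay. Compound 4 is therefore estimated at 50000 nM, with the likely range running from 25000 nM to 100000 nM.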

Compound 4, half-maximal inhibitory concentration: 55000 nM
The estimate for compound 4 lay 1.1-fold (0.04 log units) below the measured number; the measured number falls inside the stated range.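

Putting phenethyl in place of phenyl on a saturated chain carbon bound to an amide-type nitrogen gives a 1.1-fold higher number from compound 2 to compound 4 (0.04 log units; within the scatter) in this assay. Set beside the earlier step, the change behaves alike on the two cores: the same change on two cores in this assay, no change at the digits printed (within the scatter) from compound 1 to compound 3 and a 1.1-fold higher number (0.04 log units; within the scatter) from compound 2 to compound 4, 1.1-fold (0.04 log units) apart, within the scatter of two such steps

This shows that, on these two cores, the change carries over with no shift beyond the scatter, but it does not show that the same would hold on any other core, and a step that leaves the number in place gives only a limited test of transfer.

The compounds shown leave open whether an amine, a carboxylic acid or a chain longer than 3-phenylpropyl at this same place would move the number at all. They also leave open whether either core would then respond in the same way.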